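Carboxy arm extended to a carboxyphenyl on the shared core

The compounds below may be only part of what the source reports. "The series", "measured", "known", "first", "only" and "open" are said of these compounds alone.

Measured compounds:
compound 1, `CCCn1c(NCCO)nc2nc(C3CCCC3)[nH]c2c1=O`, 36%
compound 2, `CCCn1c(-c2cccc(C(=O)O)c2)nc2nc(C3CCCC3)[nH]c2c1=O`, "not active" (no number reported)
compound 3, `CCCn1c(NCC(=O)O)nc2nc(C3CCCC3)[nH]c2c1=O`, 72%

Compound 3 holds the highest of the two numbers reported in an assay on HEK293 cells for displacement of a labelled ligand from adenosine receptor A1 (Homo sapiens), with a stated time of 90 min, tested at 1 uM; a lower number here means less inhibition, a higher number more inhibition at the concentration tested (going by the name of the read-out); its nearest neighbour is compound 1, and the difference is a number 36 percentage points higher from compound 1 to compound 3 (beyond the scatter). Compound 2 was reported as "not active" (no number reported) in this assay, so no number stands for it.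

Compound 4, `CCCn1c(NCc2ccc(C(=O)O)cc2)nc2nc(C3CCCC3)[nH]c2c1=O`, has not yet been measured. Its change from compound 3 is 4-carboxyphenyl in place of carboxy on a saturated chain carbon bound to a nitrogen on an aromatic ring. Among the compounds with values here, the only step that bears on this is the one from compound 1 to compound 3, a large gain of a number 36 percentage points higher from compound 1 to compound 3 (beyond the scatter), which shows that the number is higher with a carboxy on the chain than with a hydroxymethyl. Within the data shown here, compound 2, which carries a carboxyphenyl on the ring itself, was reported as not active, but no step to compound 4 is known. A moderate loss is expected, a number 27 percentage points lower from compound 3 to compound 4 (beyond the scatter). Compound 4 is therefore estimated at 45%, within 15% to 75%.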

Compound 4, a percentage reported as inhibition, at one concentration (the size of the read-out at that concentration, not a potency): 54%
Compound 4: the middle estimate sits 9 percentage points below what was measured, within the range that was stated.
By their numbers in this assay, from the lowest: compound 1; then compound 4; then compound 3.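

In this assay, the place on a saturated chain carbon bound to a nitrogen on an aromatic ring takes 4-carboxyphenyl, with 9 heavy atoms in place of the 3 of carboxy, at a modest cost: a number 18 percentage points lower from compound 3 to compound 4 (beyond the scatter). The change adds one six-membered aromatic ring of carbon only, with the same count of hydrogen-bond donors and acceptors, and part of the gain over hydroxymethyl remains, with a number 18 percentage points higher from compound 1 to compound 4 (beyond the scatter). Nothing given here explains why the larger group lowers the number.

The compounds shown leave open whether the ring or its carboxylic acid sets the level of compound 4, a question that a plain phenyl on the same chain would address. As far as these compounds go, it also remains open how an amine in place of that carboxylic acid, or a longer chain carrying the same ring, would read in this assay.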